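The source may report more compounds than this note shows. Statements on the series, on what has been measured and on what is new or still open speak of the compounds shown alone.

Compound 1 `COc1cc(NC(C)CCCNC(=O)NNC(=O)Nc2ccc(Br)cc2)c2ncccc2c1`: 51000 nM
Compound 2 `COc1cc(NC(C)CCCNC(=O)Nc2cccc(Cl)c2)c2ncccc2c1`: 17000 nM
Compound 3 `COc1cc(NC(C)CCCNC(=O)Nc2cccc(O)c2)c2ncccc2c1`: 25000 nM

In a functional assay on L1210 cells (Mus musculus) for inhibition, read by MTT assay, with a stated time of 72 h (a higher number here means a weaker inhibitor, a lower number a stronger inhibitor), compound 3 stands second highest of the three numbers. Its nearest neighbour is compound 2, where a 1.5-fold higher number from compound 2 to compound 3 (0.17 log units; within the scatter) stays within the scatter, whereas a 2.0-fold lower number from compound 1 to compound 3 (0.31 log units; beyond the scatter) lies beyond it. Compound 4 `COc1cc(NC(C)CCCNC(=O)Nc2ccc(Cl)cc2)c2ncccc2c1` has not yet been measured; it differs from compound 3 by 4-chlorophenyl in place of 3-hydroxyphenyl on an amide-type nitrogen. The step bearing most directly on this change is a 1.5-fold higher number from compound 2 to compound 3 (0.17 log units; within the scatter), hydroxy in place of chloro on an aromatic carbon, which was within the scatter; a 3.0-fold lower number from compound 1 to compound 2 (0.48 log units; beyond the scatter) and a 2.0-fold lower number from compound 1 to compound 3 (0.31 log units; beyond the scatter) show that both aryl ureas gave lower numbers than compound 1. Compound 4 is therefore expected to sit close to compound 2, with an expected 1.4-fold lower number from compound 3 to compound 4 (0.14 log units; within the scatter) that need not exceed the scatter. For compound 4 the estimate is 18000 nM, ranging from 8000 nM to 40000 nM.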

Compound 4, half-maximal inhibitory concentration: 19000 nM
Estimate against measurement, compound 4: 1.1-fold (0.02 log units) below; measured number inside the range.
By their numbers in this assay, from the lowest: compounds 2, 4 and 3 (each within the scatter of the next); then compound 1.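

In this assay, 4-chlorophenyl on the amide-type nitrogen cannot be told apart from 3-chlorophenyl (a 1.1-fold higher number from compound 2 to compound 4 (0.05 log units; within the scatter)) or from 3-hydroxyphenyl (a 1.3-fold lower number from compound 3 to compound 4 (0.12 log units; within the scatter)). Moving the chlorine from the 3-chlorophenyl to the 4-chlorophenyl arrangement therefore registers no more than exchanging 3-hydroxyphenyl did, and the third aryl urea also stands clear of compound 1 (a 2.7-fold lower number from compound 1 to compound 4 (0.43 log units; beyond the scatter)). The compounds shown leave open whether an amine or a carboxylic acid on the phenyl ring would carry the number beyond the scatter. No measurement shown here accounts for how closely these three ureas agree.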